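Dihydropyranyl in place of methyl on the triazole core

A few compounds are considered here, and "the series" means these few. Any claim that something is new, unique, unknown or untested is made for them only; others in the source may bear on it.

Compound 1 `Cc1nnn(Cc2ccc(C(F)(F)F)cc2)c1C(=O)N[C@@H](C)c1ccc(C(=O)O)cc1` was tested in a functional assay on CHO cells for antagonist activity at prostaglandin E2 receptor EP4 subtype (Homo sapiens), read by calcium flux, with a stated time of 15 min (a lower number here means a stronger inhibitor, a higher number a weaker inhibitor), and gave only a limit, > 10000 nM. It thus sits at the limit of > 10000 nM in this assay, at which 1 of the 3 values shown sits. Within the data shown here, compound 2 `COc1ccc(Cn2nnc(-c3ccccc3)c2C(=O)N[C@@H](C)c2ccc(C(=O)O)cc2)cc1F` gives 29.8 nM in this assay, and compound 3 `COc1ccc(Cn2nnc(-c3ccccc3)c2C(=O)N[C@@H](C)c2ccc(C(=O)O)cc2)cc1OC` gives 119 nM; the one measured step, a 4.0-fold higher number from compound 2 to compound 3 (0.60 log units; beyond the scatter), concerns the benzyl ring and not the ring carbon changed here. Compound 4 `C[C@H](NC(=O)c1c(C2=CCOCC2)nnn1Cc1ccc(C(F)(F)F)cc1)c1ccc(C(=O)O)cc1` differs from compound 1 by a group of 6 heavy atoms (5 carbon, 1 oxygen; one six-membered non-aromatic ring with 1 hetero atom) in place of one carbon atom, on an aromatic carbon. Among the measured compounds shown here, no measured step bears directly on this change; compounds 2 and 3, which carry a phenyl on that carbon and reach nanomolar numbers, are the only guide. Compound 4 is therefore expected to be markedly stronger than compound 1, a step of an at least 66-fold lower number from compound 1 to compound 4 (1.82 log units; beyond the scatter), with an estimate of 150 nM and a range from 25 nM to 2500 nM.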

Compound 4, half-maximal inhibitory concentration: 119 nM
For compound 4 the middle estimate is 1.3-fold (0.10 log units) above the measured one, within the range that was stated.
By their numbers in this assay, from the lowest: compound 2; then compounds 3 and 4 (each within the scatter of the next). At a limit, above all of these: compound 1.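

In this assay, the step on this aromatic carbon is large: an at least 84-fold lower number from compound 1 to compound 4 (1.92 log units; beyond the scatter). The earlier nanomolar numbers came only with a phenyl on this carbon, whereas compound 4 reaches one with a six-membered non-aromatic ring, and it does so with the trifluoromethyl benzyl group of compound 1 kept. The starting point of the step is only a limit, held by compound 1: the limit of > 10000 nM in this assay, at which 1 of the 4 values shown sits.

As far as these compounds go, what a tetrahydropyranyl or a cyclohexenyl group would give on this carbon stays open, and with it whether the ring oxygen or the double bond matters. So does the effect of a small chain such as ethyl.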